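A few compounds are considered here, and "the series" means these few. Any claim that something is new, unique, unknown or untested is made for them only; others in the source may bear on it.

Working notes on the series. Compound 3 `Cc1cccc(-n2nncc2CN2C(=O)C3(C(C#N)=C(N)Oc4c(N)cc5nc6ccccc6nc5c43)c3ccccc32)c1` is measured in a functional assay on HCT-116 cells (Homo sapiens) for antiproliferative activity, read by MTT assay, with a stated time of 48 h; a lower number here means a stronger inhibitor, a higher number a weaker inhibitor. In this assay compound 3 gives > 50000 nM, which is a limit of the assay and not a number. The two further values shown are limits as well. Compound 1 `N#CC1=C(N)Oc2c(c3nc4ccccc4nc3c3ccccc23)C12C(=O)N(Cc1cnnn1-c1ccc([N+](=O)[O-])cc1)c1ccccc12` in this assay gives > 50000 nM, a limit. Compound 2 `Cc1ccc(-n2nncc2CN2C(=O)C3(C(C#N)=C(N)Oc4c3c3nc5ccccc5nc3c3ccccc43)c3ccccc32)c(C)c1` in this assay gives > 50000 nM, again a limit. The step that the two limits leave unreadable from compound 1 to compound 2 cannot be read because the limit of > 50000 nM in this assay, at which 3 of the 3 values shown sit, holds both of its ends.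

Compound 4 `CCc1cccc(CC)c1-n1nncc1CN1C(=O)C2(C(C#N)=C(N)Oc3c(N)cc4nc5ccccc5nc4c32)c2ccccc21` differs from compound 3 in one place: 2,6-diethylphenyl in place of 3-methylphenyl on an aromatic nitrogen. Among the compounds with values here, the one measured step at the same aromatic nitrogen is a step that the two limits leave unreadable from compound 1 to compound 2, and it leaves no size to carry over. Within the data shown here, no step of readable size bears on this change. Compound 3 stands at a limit, and a further exchange of the group on that aromatic nitrogen gives no ground to expect the limit to be left. The step of a number no higher from compound 3 to compound 4 (the limit leaves the size open) is therefore expected to be none beyond the scatter, most likely reported once more as a limit. Compound 4 is expected to give 50000 nM in this assay, with a range from 20000 nM to 200000 nM.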

Compound 4, half-maximal inhibitory concentration: 37600 nM
The estimate for compound 4 lay 1.3-fold (0.12 log units) above the measured number; low and high end bracket the measured number.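

In this assay, compound 4 gives 37600 nM, the first number in the series shown. The group on this aromatic nitrogen is therefore not shown to be tied to the limit on this core. The exchange of 3-methylphenyl for 2,6-diethylphenyl gives an at least 1.3-fold lower number from compound 3 to compound 4 (0.12 log units; that floor lies within the scatter). That step has only a floor, and whether the true change lies beyond the scatter cannot be read: the limit of > 50000 nM in this assay, at which 3 of the 4 values shown sit.

As far as these compounds go, whether 2,6-dimethylphenyl, with shorter chains in place of the two ethyl groups, would keep a measurable value remains open. So does the effect on the number of a phenyl ring carrying an amine or a carboxylic acid, or of a benzyl group, on this nitrogen.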